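From compound 3 to compound 4: one group exchanged

A few compounds are considered here, and "the series" means these few. Any claim that something is new, unique, unknown or untested is made for them only; others in the source may bear on it.

In a functional assay (blood) for inhibition, with Homo sapiens as the target (on this read-out higher numbers stand for weaker inhibition and lower numbers for stronger inhibition), compound 1 `CC(C)(C)Sc1c(CC(C)(C)C(=O)O)n(Cc2ccc(Cl)cc2)c2ccc(CCc3ccc4ccccc4n3)cc12` gives > 3000 nM, which is a limit and not a number. Compound 2 `CC(C)(C)Sc1c(CC(C)(C)C(=O)O)n(Cc2ccc(Cl)cc2)c2ccc(OCc3ccc4cccnc4n3)cc12` gives > 3000 nM, again a limit. For the measured compounds named here, compound 3 `CC(C)(C)Sc1c(CC(C)(C)C(=O)O)n(Cc2ccc(Cl)cc2)c2ccc(OCc3ccc4cnccc4n3)cc12` gives 980 nM, the only true number so far. Compound 4 `CC(C)(C)Sc1c(CC(C)(C)C(=O)O)n(Cc2ccc(Cl)cc2)c2ccc(OCc3nc4ccccc4o3)cc12` differs from it by a group of 9 heavy atoms (7 carbon, 1 nitrogen, 1 oxygen; one five-membered aromatic ring with 2 hetero atoms, one six-membered aromatic ring of carbon only) in place of a group of 10 heavy atoms (8 carbon, 2 nitrogen; 2 six-membered aromatic rings with 1 hetero atom each), on a saturated chain carbon bound to an oxygen on an aromatic ring. The closest guide is an at least 3.0-fold lower number from compound 2 to compound 3 (0.48 log units; beyond the scatter), an exchange at this same place, which shows that a small change here can matter. The step of an at least 3.0-fold lower number from compound 1 to compound 3 (0.48 log units; beyond the scatter) replaces a larger stretch and guides less. Neither step shows how a 1,3-benzoxazol-2-yl group will behave, so the expected step, a 1.5-fold higher number from compound 3 to compound 4 (0.18 log units; within the scatter), stays within the scatter. For compound 4 the estimate is 1500 nM, with an expected range from 500 nM to 4500 nM.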

Compound 4, half-maximal inhibitory concentration: 2500 nM
Estimate against measurement, compound 4: 1.7-fold (0.22 log units) below, and the stated range covers the measured number.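

In this assay there is a 2.6-fold higher number from compound 3 to compound 4 (0.41 log units; beyond the scatter), so on this saturated chain carbon the 1,3-benzoxazol-2-yl group gives weaker inhibition than the group it replaces. Against the earlier compounds only floors can be read, an at least 1.2-fold lower number from compound 2 to compound 4 (0.07 log units; that floor lies within the scatter) and an at least 1.2-fold lower number from compound 1 to compound 4 (0.07 log units; that floor lies within the scatter), so compound 4 cannot be ranked against either. Those two compounds stop at a limit and not at a number: the limit of > 3000 nM in this assay, at which 2 of the 4 values shown sit.

Still open, going by these compounds, is how a single ring on this carbon, such as phenyl or pyridin-2-yl, would compare with the two-ring groups.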